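Swapping a Saturated Ring for an Aromatic One

The source may report more compounds than this note shows. Statements on the series, on what has been measured and on what is new or still open speak of the compounds shown alone.

Three compounds share a core that ends in the same amide-linked benzyl group bearing a chloro and a trifluoromethyl substituent. Compound 1 `CN1C(=O)C(C)(C)C[C@H]1C(=O)NCc1cccc(C(F)(F)F)c1Cl` gives 25.1 nM in a functional assay on HEK293 cells for antagonist activity at P2X purinoceptor 7 (Homo sapiens); on this read-out lower numbers stand for stronger inhibition and higher numbers for weaker inhibition. Compound 2 `CN1C(=O)COC[C@H]1C(=O)NCc1cccc(C(F)(F)F)c1Cl` gives 3.98 nM in this assay. Compound 3 `CN1CCC(N2C[C@@H](C(=O)NCc3cccc(C(F)(F)F)c3Cl)N(C)C2=O)CC1` gives 31.6 nM in this assay, which is the highest of the three numbers: its gap to compound 1 lies within the usual scatter, while its gap to compound 2 lies well beyond it.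

Compound 4 `Cc1cccc(N2C[C@@H](C(=O)NCc3cccc(C(F)(F)F)c3Cl)N(C)C2=O)n1` has not yet been measured. It differs from compound 3 in one place: 6-methylpyridin-2-yl in place of 1-methylpiperidin-4-yl on an amide-type nitrogen in a ring. Going by the values given here, no pair of measured compounds shows what this kind of swap does, so the expectation rests on the single change alone. The size of the group stays the same and its hydrogen-bond count stays the same; the saturated ring becomes an aromatic one. The expected step from compound 3 to compound 4 in this assay is a 1.6-fold lower number from compound 3 to compound 4 (0.20 log units; within the scatter), a modest lowering that may well fall within the scatter. Compound 4 is therefore estimated at 20 nM, with a range from 5 nM to 80 nM.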

Compound 4, half-maximal inhibitory concentration: 79.4 nM
Beside the measured number, compound 4's estimate is 4.0-fold (0.60 log units) below it, within the range that was stated.
By their numbers in this assay, from the lowest: compound 2; then compounds 1 and 3 (each within the scatter of the next); then compound 4.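

On the amide-type nitrogen in the five-membered ring, placing 6-methylpyridin-2-yl where 1-methylpiperidin-4-yl stood gives a 2.5-fold higher number from compound 3 to compound 4 (0.40 log units; beyond the scatter) in this assay. Inhibition at this position therefore weakens when the saturated ring becomes an aromatic one, even though the heavy-atom and hydrogen-bond counts of the group stay the same. Nothing available explains why these two groups differ.

Going by these compounds alone, with only this one pair at the position, it remains open whether the step follows from the aromatic ring itself, its ring nitrogen or its methyl group. Phenyl, unsubstituted pyridin-2-yl and piperidin-4-yl without the methyl group on nitrogen are among the groups that could help separate these features.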